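The source may hold more compounds than are shown below. What is called first, only, known or untested is meant among the compounds shown, and "the series" means these compounds.

Of the compounds shown here, three have been tested in an assay on isolated protein for inhibition of microsomal triglyceride transfer protein large subunit (Homo sapiens); on this read-out lower numbers stand for stronger inhibition and higher numbers for weaker inhibition. Compound 1 `COC(=O)N[C@H]1Cc2ccc(NC(=O)c3ccccc3-c3ccc(C(F)(F)F)cc3)cc2C1` gives 68 nM. For the measured compounds named here, compound 2 `COC(=O)N[C@H]1Cc2ccc(NC(=O)c3cc(C(F)(F)F)ccc3-c3ccc(C(F)(F)F)cc3)cc2C1` gives 410 nM; the one change between them, trifluoromethyl in place of hydrogen on an aromatic carbon, brings a 6.0-fold higher number from compound 1 to compound 2 (0.78 log units; beyond the scatter). Compound 3 `Cc1cccc(C(=O)Nc2ccc3c(c2)CC(NS(=O)(=O)c2ccccc2)C3)c1-c1ccc(F)cc1`, built on a different core, gives 240 nM. That is the second highest of the three numbers: it lies within the scatter of compound 2, while compound 1 sits lower by a margin beyond the scatter.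

Compound 4 `Cc1cccc(C(=O)Nc2ccc3c(c2)CC(NS(=O)(=O)c2ccccc2)C3)c1-c1ccc(C#N)cc1` differs from compound 3 in one place: cyano in place of fluoro on an aromatic carbon, the fluoro sitting on an aromatic carbon of a six-membered aromatic ring of carbon only, para to a large group. Going by the values given here, no measured step involves fluoro or cyano, and the only measured step belongs to the other core, so nothing measured bears directly on this change. For compound 4 the expectation in this assay is a step of a 1.1-fold lower number from compound 3 to compound 4 (0.04 log units; within the scatter) that does not reach beyond the scatter. Compound 4 is therefore estimated at 220 nM in this assay, with a range from 70 nM to 700 nM.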

Compound 4, half-maximal inhibitory concentration: 120 nM
Compound 4: the middle estimate sits 1.8-fold (0.26 log units) above what was measured, and the stated range covers the measured number.
By their numbers in this assay, from the lowest: compounds 1, 4, 3 and 2 (each within the scatter of the next, the first and the last beyond it).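

In this assay, going from 4-fluorophenyl to 4-cyanophenyl brings a 2.0-fold lower number from compound 3 to compound 4 (0.30 log units; within the scatter) and so does not separate the two groups on this read-out. For the compounds shown here, this is the only measured step at this place, on an aromatic carbon of a six-membered aromatic ring of carbon only, para to a large group. It shows that cyano, with two heavy atoms and one hydrogen-bond acceptor, can stand there in place of a single fluorine without a step beyond the scatter, although nothing shown explains why the two groups read alike.

Still open, going by these compounds, is how an amine, a carboxylic acid or a longer chain such as an n-butyl group would read at this same place, since two groups say little about how much room for change the position allows. Going by these compounds alone, also open is whether cyano in place of fluoro would give a similar step on the core of compound 1, as the one change measured on that core involves a different group at a different place.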